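Methyl to Propyl on the Amide Partner of Compound 1

The compounds below may be only part of what the source reports. "The series", "measured", "known", "first", "only" and "open" are said of these compounds alone.

Compound 1 `Cc1ccc(C(=O)Nc2cccc(-c3oc4cc(-c5ccc(F)cc5)ccc4c(=O)c3O)c2)cc1` carries a 4-methylphenyl group on the carbonyl carbon of its amide. Within the data shown here, in a functional assay on HCC1937 cells (Homo sapiens) for antiproliferative activity, read by CCK-8 assay, with a stated time of 72 h (on this read-out higher numbers stand for weaker inhibition and lower numbers for stronger inhibition), compound 1 gives 7110 nM, the lowest of the two numbers measured so far. Among the measured compounds shown here, its only neighbour is compound 2 `COc1ccc(C(=O)Nc2cccc(-c3oc4cc(-c5ccc(F)cc5)ccc4c(=O)c3O)c2)c(F)c1`, which in this assay gives 24500 nM; the step of a 3.4-fold higher number from compound 1 to compound 2 (0.54 log units; beyond the scatter) comes with a 2-fluoro-4-methoxyphenyl in place of the 4-methylphenyl on the carbonyl carbon.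

Compound 3 `CCCc1ccc(C(=O)Nc2cccc(-c3oc4cc(-c5ccc(F)cc5)ccc4c(=O)c3O)c2)cc1` has not yet been measured. It differs from compound 1 by ethyl in place of hydrogen on a saturated chain carbon bound to an aromatic carbon, so that the 4-methylphenyl becomes a 4-propylphenyl. For the measured compounds named here, the single measured step alters a different set of groups and bears on this change only loosely; it does show that the aryl group on the carbonyl carbon can move the number by a modest amount. Going by the values given here, no measured step lengthens the chain at this place, so the direction here is open. Compound 3 is therefore expected to stay close to compound 1, with a step of a 1.2-fold lower number from compound 1 to compound 3 (0.07 log units; within the scatter) that may well lie within the scatter. The estimate for compound 3 in this assay is 6000 nM, between 2500 nM and 15000 nM.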

Compound 3, half-maximal inhibitory concentration: 15400 nM
Compound 3: the middle estimate sits 2.6-fold (0.41 log units) below what was measured; measured number above the stated range.
By their numbers in this assay, from the lowest: compound 1; then compounds 3 and 2 (each within the scatter of the next).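

Among these compounds, the lengthening of methyl to propyl is the first change of chain length seen at this place, and in this assay it gives a 2.2-fold higher number from compound 1 to compound 3 (0.34 log units; beyond the scatter) and does not lower the number, so compound 1 keeps the lowest value of the three. The earlier step had shown only that a change of the whole aryl group on the carbonyl carbon can raise the number, whereas this one shows that adding an ethyl on the saturated chain carbon bound to an aromatic carbon is enough to do so, with a step of similar order. The 4-propylphenyl and the 2-fluoro-4-methoxyphenyl cannot be told apart in this assay, since a 1.6-fold lower number from compound 2 to compound 3 (0.20 log units; within the scatter) leaves the two values together, and nothing measured here accounts for the rise from the methyl.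

As far as these compounds go, with only methyl and propyl in view, it stays open whether an ethyl on the same aryl group would already give the higher number and whether a longer chain such as pentyl would raise it further. The compounds shown also leave open how a hydroxyl or an amine at the end of the propyl chain would read in this assay.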